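The compounds below may be only part of what the source reports. "The series", "measured", "known", "first", "only" and "open" are said of these compounds alone.

In an ADME assay on HEK-293T cells (Homo sapiens) for cytotoxicity, read by MTT assay, with a stated time of 3 days (a lower number here means that less compound is tolerated, a higher number that more compound is tolerated), compound 1 `CC(C)OC(=O)COC(=O)c1ccc([N+](=O)[O-])o1` gives > 100000 nM, which is a limit of the assay and not a number. Compound 2 `CC(C)(C)NC(=O)COC(=O)c1ccc([N+](=O)[O-])o1` gives > 100000 nM, again a limit. Compound 3 `CC(C)(C)N(CCCc1ccccc1)C(=O)COC(=O)c1ccc([N+](=O)[O-])o1` has no single number and is reported only as "not active" (no number reported). The values around it therefore offer (the limit of > 100000 nM in this assay, at which 2 of the 3 values shown sit).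

Compound 4 `CC(=O)Oc1ccc(CN(C(=O)COC(=O)c2ccc([N+](=O)[O-])o2)C(C)(C)C)cc1` departs from compound 3 in one place, with 4-acetoxyphenyl in place of phenethyl on a saturated chain carbon bound to an amide-type nitrogen.

Among the measured compounds shown here, only one measured step bears on this change, and only indirectly. It is a step that the two limits leave unreadable from compound 1 to compound 2, which puts (tert-butyl)amino in place of isopropoxy on a carbonyl carbon, a different change from the one at hand. It supplies no size to carry over. Nothing in these data shows a measurable fall in the tolerated concentration for any compound of the series. With compound 3 reported as "not active" (no number reported), no step beyond the scatter is expected in this assay, in either direction. The likeliest report for compound 4 is again a limit. Compound 4 is expected at about 100000 nM, with an estimated range from 40000 nM to 200000 nM.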

Compound 4, half-maximal cytotoxic concentration: > 100000 nM
Compound 4: no number, only a limit (the forecaster's own chance of this, stated with the estimate: 75%); the middle value lies on the limit itself.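

In this assay compound 4 gives > 100000 nM, which is a limit of the assay and not a number. Compound 3 has no single number either, so no step can be read between compound 3 and compound 4. The compounds shown leave open what concentration of any of them is actually tolerated: the limit of > 100000 nM in this assay, at which 3 of the 4 values shown sit.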